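Chloro in Place of Methoxy on an Unresponsive Amide Series

The source may report more compounds than this note shows. Statements on the series, on what has been measured and on what is new or still open speak of the compounds shown alone.

Measured so far in a functional assay on L02 cells (Homo sapiens) for inhibition, read by MTT assay, with a stated time of 48 h; on this read-out lower numbers stand for stronger inhibition and higher numbers for weaker inhibition:
compound 1, `COc1ccc2c(=O)c(/C=C/C(=O)Nc3ccccc3Cl)coc2c1`, gives > 200000 nM, a limit of the assay.
compound 2, `COc1cccc(NC(=O)/C=C/c2coc3cc(OC)ccc3c2=O)c1`, gives > 200000 nM, a limit of the assay.
compound 3, `COc1ccc(NC(=O)/C=C/c2coc3cc(OC)ccc3c2=O)cc1`, gives > 200000 nM, a limit of the assay.

Compound 3 stands at the same limit as the other two. Its value is not a number but the ceiling of this assay, and so its rank against compound 1 and compound 2 cannot be read from these figures.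

Compound 4, `COc1ccc2c(=O)c(/C=C/C(=O)Nc3ccc(Cl)cc3)coc2c1`, differs from compound 3 by chloro in place of methoxy on an aromatic carbon.

The measured steps that touch this region of the amide-type nitrogen are a step that the two limits leave unreadable from compound 1 to compound 2, a step that the two limits leave unreadable from compound 1 to compound 3 and a step that the two limits leave unreadable from compound 2 to compound 3. All three are unreadable, because of the limit of > 200000 nM in this assay, at which 3 of the 3 values shown sit. Changes of the substituent on this ring therefore show no measurable effect in this assay across the three compounds, and there is nothing that points to a step of any size or direction.

Compound 4 is accordingly expected to sit at the same limit, with an estimated step that the limit leaves unreadable from compound 3 to compound 4. The estimate for compound 4 in this assay is 250000 nM, within a range from 60000 nM to 1000000 nM.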

Compound 4, half-maximal inhibitory concentration: > 200000 nM
Compound 4 was reported as a limit; the forecaster's own chance of this, stated with the estimate: 85%; the middle value lies beyond the limit too.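

In this assay compound 4 gives > 200000 nM, which is a limit of the assay and not a number. No step from compound 1, compound 2 or compound 3 to compound 4 can be read, because all four compounds share one limit: the limit of > 200000 nM in this assay, at which 4 of the 4 values shown sit.

The compounds shown leave open whether the substituent on this ring affects inhibition at all.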